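Chlorophenyl ether series: outlook for compound 3

This account rests on a few compounds, and the source may have more. Where it says the series, first, only, none or still open, it means among the compounds named here.

Going by the values given here, in a functional assay on cells for antagonist activity at Free fatty acid receptor 1 (Homo sapiens), read by TR-FRET and inositol phosphate accumulation, with a stated time of 2 h (a lower number here means a stronger inhibitor, a higher number a weaker inhibitor), compound 2 `Cc1cc(COc2cccc(Cl)c2)nc(-c2ccccn2)n1` gives 398 nM, the highest of the two numbers so far; the nearest is compound 1 `Cc1cc(COc2ccccc2Cl)nc(-c2ccccn2)n1`, which in this assay gives 316 nM. The one step between them, a 1.3-fold higher number from compound 1 to compound 2 (0.10 log units; within the scatter), lies within the scatter, so on the numbers shown the two cannot be separated.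

Compound 3 `Cc1cc(COc2ccc(Cl)cc2)nc(-c2ccccn2)n1` has not been measured. It differs from compound 2 by 4-chlorophenyl in place of 3-chlorophenyl on an oxygen on a saturated carbon. Among the compounds with values here, the only measured step that bears on this change is a 1.3-fold higher number from compound 1 to compound 2 (0.10 log units; within the scatter), which stayed within the scatter. On that basis the present change is expected to leave the number where it is, with no direction to call, and for compound 3 the expected step is a 1.0-fold higher number from compound 2 to compound 3 (0.00 log units; within the scatter). The estimate for compound 3 in this assay is 400 nM, with a range from 150 nM to 1100 nM. Within the data shown here, the range is kept wide: only one step, a 1.3-fold higher number from compound 1 to compound 2 (0.10 log units; within the scatter), informs it, and it is a step within the scatter.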

Compound 3, half-maximal inhibitory concentration: 251 nM
Estimate against measurement, compound 3: 1.6-fold (0.20 log units) above, and the stated range covers the measured number.
By their numbers in this assay, from the lowest: compounds 3, 1 and 2 (each within the scatter of the next).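

In this assay, 4-chlorophenyl in place of 3-chlorophenyl on an oxygen on a saturated carbon gives a 1.6-fold lower number from compound 2 to compound 3 (0.20 log units; within the scatter), and 4-chlorophenyl in place of 2-chlorophenyl gives a 1.3-fold lower number from compound 1 to compound 3 (0.10 log units; within the scatter). With 2-chlorophenyl, 3-chlorophenyl and 4-chlorophenyl now all represented, every printed step among the three compounds lies within the scatter, so moving the chlorine around this phenyl ring has produced no readable change in this set, where the earlier pair could speak for only two of the three placements. Nothing available on these compounds offers an explanation for how closely the three numbers sit together.

On these data alone, since all three compounds carry a single chlorine on the phenyl ring, it remains open whether the flat response extends to other groups there, such as a methoxy group, an amine or a carboxylic acid, or to a phenyl ring with no chlorine at all. As far as these compounds go, the shared core and the link through the oxygen are also identical throughout, so the effect of a longer chain in that link remains unknown.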